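Swapping pyridin-2-yl for ethoxy on a shared core

This account rests on a few compounds, and the source may have more. Where it says the series, first, only, none or still open, it means among the compounds named here.

Measured so far in a functional assay on HepG2 cells (Homo sapiens) for inhibition, read by MTT assay, with a stated time of 72 h; on this read-out lower numbers stand for stronger inhibition and higher numbers for weaker inhibition
- Compound 1 `COc1ccc(-c2cc(C(=O)N3CCC4(CC3)CC(=O)c3nn(C(C)(C)C)cc3O4)c3ccccc3n2)cc1OC` gives 1560 nM
- Compound 2 `CC(C)(C)n1cc2c(n1)C(=O)CC1(CCN(C(=O)c3cc(-c4ccc(N)cc4)nc4ccccc34)CC1)O2` gives 630 nM
- Compound 3 `CC(C)(C)n1cc2c(n1)C(=O)CC1(CCN(C(=O)c3cc(-c4ccccn4)nc4ccccc34)CC1)O2` gives 1500 nM

Not yet measured
- Compound 4 `CCOc1cc(C(=O)N2CCC3(CC2)CC(=O)c2nn(C(C)(C)C)cc2O3)c2ccccc2n1`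

Compound 3 belongs to the upper end of these numbers. The step of a 1.0-fold lower number from compound 1 to compound 3 (0.02 log units; within the scatter) leaves it level with its closest neighbour, while a 2.4-fold higher number from compound 2 to compound 3 (0.38 log units; beyond the scatter) sets it clearly above the remaining value.

Compound 4 carries ethoxy in place of pyridin-2-yl on an aromatic carbon. Among the measured compounds shown here, all three measured compounds hold a ring group on this same carbon, and the steps among them are the only guide available. Swapping those groups gave a 2.5-fold lower number from compound 1 to compound 2 (0.39 log units; beyond the scatter), a modest change, and the other two steps are the ones already described. For the measured compounds named here, none of the measured compounds shows what a group with no ring does here, so this step goes beyond what has been tested. Given such small steps in this assay, no large move is expected, only perhaps a slight rise that stays inside the scatter. The expected step is a 1.3-fold higher number from compound 3 to compound 4 (0.12 log units; within the scatter). For compound 4 the estimated value is 2000 nM, with an expected range from 700 nM to 6000 nM.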

Compound 4, half-maximal inhibitory concentration: > 10000 nM
Compound 4: a limit, no number; the forecaster's own chance of this, stated with the estimate: 10%; at least 5.0-fold (0.69 log units) between middle value and limit.
By their numbers in this assay, from the lowest: compound 2; then compounds 3 and 1 (each within the scatter of the next). At a limit, above all of these: compound 4.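

In this assay compound 4 gives > 10000 nM, which is a limit of the assay and not a number. All three steps to it lie beyond the scatter: an at least 6.6-fold higher number from compound 3 to compound 4 (0.82 log units; beyond the scatter), an at least 6.4-fold higher number from compound 1 to compound 4 (0.80 log units; beyond the scatter) and an at least 15-fold higher number from compound 2 to compound 4 (1.20 log units; beyond the scatter). Among the earlier compounds, the groups pyridin-2-yl, 4-aminophenyl and 3,4-dimethoxyphenyl on this aromatic carbon next to the ring nitrogen gave only modest steps or none beyond the scatter, so this position looked tolerant of change, whereas ethoxy, the one group here with no ring, shows that the read-out does depend on what sits there.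

Going by these compounds, one group cannot show whether the ring itself matters or some other difference between ethoxy and the ring groups, so it remains open whether a cyclopropyl group, a longer chain such as butoxy, or an amine joined through its nitrogen would stay near the ring groups or go the way of ethoxy. On these data alone, the true size of the loss also stays open, as each of the three steps gives only a lower bound.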